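The source may report more compounds than this note shows. Statements on the series, on what has been measured and on what is new or still open speak of the compounds shown alone.

Measured in a functional assay on MCF7 cells (Homo sapiens) for antiproliferative activity, read by MTT assay, with a stated time of 48 h; on this read-out higher numbers stand for weaker inhibition and lower numbers for stronger inhibition:
compound 1 `O=C(Nc1cccc(/C=C/C(=O)c2nc3ccccc3[nH]2)c1)c1ccccc1`: 11200 nM
compound 2 `O=C(Nc1cccc(/C=C/C(=O)c2nc3ccccc3[nH]2)c1)c1cccc(Cl)c1`: 7840 nM
compound 3 `O=C(Nc1cccc(/C=C/C(=O)c2nc3ccccc3[nH]2)c1)c1ccc(Br)cc1`: 7000 nM

Compound 3 has the lowest of the three numbers, but its gaps to compound 2 and compound 1 both lie within the scatter, so no order among the three can be read. Compound 4 `Cc1ccc(S(=O)(=O)Nc2cccc(/C=C/C(=O)c3nc4ccccc4[nH]3)c2)cc1` differs from compound 3 as follows: (4-methylphenyl)sulfonyl in place of (4-bromophenyl)carbonyl on a nitrogen on an aromatic ring. The measured steps concern only halogen substitution on the aromatic ring, a 1.4-fold lower number from compound 1 to compound 2 (0.15 log units; within the scatter) and a 1.6-fold lower number from compound 1 to compound 3 (0.20 log units; within the scatter), and the shift a 1.1-fold lower number from compound 2 to compound 3 (0.05 log units; within the scatter); none exchanges the carbonyl for a sulfonyl, so they bear on this change only indirectly. Given how flat the series is, no step beyond the scatter is expected, a 1.1-fold higher number from compound 3 to compound 4 (0.03 log units; within the scatter). Compound 4 is estimated at 7500 nM, within 3000 nM to 18000 nM.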

Compound 4, half-maximal inhibitory concentration: 3220 nM
Estimate against measurement, compound 4: 2.3-fold (0.37 log units) above, and the stated range covers the measured number.
By their numbers in this assay, from the lowest: compound 4; then compounds 3, 2 and 1 (each within the scatter of the next).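

In this assay, going by these compounds alone, the nitrogen on the aromatic ring is the first place where a change goes beyond the scatter: (4-methylphenyl)sulfonyl in place of (4-bromophenyl)carbonyl gives a 2.2-fold lower number from compound 3 to compound 4 (0.34 log units; beyond the scatter) as a modest step. The same holds against the other two carbonyl groups, with a 2.4-fold lower number from compound 2 to compound 4 (0.39 log units; beyond the scatter) and with a 3.5-fold lower number from compound 1 to compound 4 (0.54 log units; beyond the scatter) as modest steps, whereas halogen in place of hydrogen stayed within the scatter. No measurement here bears on the cause of these steps.

The sulfonyl and the 4-methyl group enter together, so their shares stay unseparated. Phenylsulfonyl and methylsulfonyl on the same nitrogen would separate them.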